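Compound 2 to compound 3: one group exchanged

A few compounds are considered here, and "the series" means these few. Any claim that something is new, unique, unknown or untested is made for them only; others in the source may bear on it.

Values in an ADME assay on HepG2 cells (Homo sapiens) for cytotoxicity, read by MTT assay, with a stated time of 24 h (on this read-out lower numbers stand for higher toxicity in this test and higher numbers for lower toxicity in this test), for the two compounds measured so far
- compound 1 `CC(C)=CCC1=C(OCc2cn(-c3ccnc4cc(Cl)ccc34)nn2)C(=O)c2ccccc2C1=O` gives 1940000 nM
- compound 2 `COc1cc([N+](=O)[O-])ccc1-n1cc(COC2=C(CC=C(C)C)C(=O)c3ccccc3C2=O)nn1` gives 701000 nM

Compound 2 holds the lower of these two numbers, which makes it the more toxic of the pair in this test. Compound 3 `CC(C)=CCC1=C(OCc2cn(-c3ccccc3C)nn2)C(=O)c2ccccc2C1=O` has not yet been measured. It keeps the core of compound 2 and differs only in the group on an aromatic nitrogen of the five-membered ring, with 2-methylphenyl in place of 2-methoxy-4-nitrophenyl (2-methylphenyl in place of 2-methoxy-4-nitrophenyl on an aromatic nitrogen). Going by the values given here, one measured step bears on this, at the same nitrogen (a 2.8-fold lower number from compound 1 to compound 2 (0.44 log units; beyond the scatter)). That modest step, beyond the scatter, shows that the group here can move the number, but it says nothing direct about 2-methylphenyl. Among the compounds with values here, compound 2 at 701000 nM is the lower of only two numbers, so a smaller step upward in this assay is expected rather than a further fall. The expected change is a 1.9-fold higher number from compound 2 to compound 3 (0.27 log units; within the scatter) as an estimate. For compound 3 the estimated value is 1300000 nM, with an expected range from 550000 nM to 3000000 nM as its limits of confidence.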

Compound 3, half-maximal cytotoxic concentration: 256000 nM
For compound 3 the middle estimate is 5.1-fold (0.71 log units) above the measured one, and the stated range ends above it.
By their numbers in this assay, from the lowest: compound 3; then compound 2; then compound 1.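

In this assay, putting 2-methylphenyl in place of 2-methoxy-4-nitrophenyl on the aromatic nitrogen gives a 2.7-fold lower number from compound 2 to compound 3 (0.44 log units; beyond the scatter), so this exchange, like the earlier one at the same nitrogen, moves the number beyond the scatter. The entering group has 7 heavy atoms and no hydrogen-bond acceptors, against 11 heavy atoms and 3 acceptors in the group that leaves, yet it carries the lowest number of the three and so the highest toxicity in this test. Set against 7-chloroquinolin-4-yl, the same group gives a 7.6-fold lower number from compound 1 to compound 3 (0.88 log units; beyond the scatter), the widest gap seen so far, which shows how far the number can travel with a change at this one place while the shared core stays the same, although nothing measured here accounts for this order.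

The compounds shown leave open what a phenyl ring without the methyl group would give at this nitrogen, or one carrying an amine or a carboxylic acid. They also cannot separate the methoxy group from the nitro group, since both leave together, and they cannot tell whether this order would hold on a different core.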